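This account rests on a few compounds, and the source may have more. Where it says the series, first, only, none or still open, it means among the compounds named here.

In an assay on HEK293 cells for inhibition of Fatty-acid amide hydrolase 1 (Homo sapiens), read by fluorescence (on this read-out lower numbers stand for stronger inhibition and higher numbers for weaker inhibition), compound 1 `Cn1ccc2cc(-c3ccc4oc(Nc5ccccc5)nc4c3)ccc21` gives 48 nM, compound 2 `Cn1ccc2cc(-c3ccc4oc(Cc5ccccc5)nc4c3)ccc21` gives 488 nM, and compound 3 `C[C@@H]1CN(c2nc3cc(-c4ccc5c(ccn5C)c4)ccc3o2)C[C@H](C)O1` gives 168 nM. Compound 3 thus stands second highest of the three numbers. a 2.9-fold lower number from compound 2 to compound 3 (0.46 log units; beyond the scatter), and a 3.5-fold higher number from compound 1 to compound 3 (0.54 log units; beyond the scatter). Compound 4 `Cn1ccc2cc(-c3ccc4oc(N5CCn6cccc6C5)nc4c3)ccc21` has not yet been measured in this assay; it differs from compound 3 in that (a group of 9 heavy atoms (7 carbon, 2 nitrogen; one five-membered aromatic ring with 1 hetero atom, one six-membered non-aromatic ring with 2 hetero atoms) in place of a group of 8 heavy atoms (6 carbon, 1 nitrogen, 1 oxygen; one six-membered non-aromatic ring with 2 hetero atoms), on an aromatic carbon). Going by the values given here, no measured step exchanges one such group for another, so the bearing of the known steps is indirect: a 10-fold higher number from compound 1 to compound 2 (1.01 log units; beyond the scatter) and a 3.5-fold higher number from compound 1 to compound 3 (0.54 log units; beyond the scatter) show that the anilino group of compound 1 is hard to match. Compound 4 is expected to stay close to compound 3, a 1.3-fold lower number from compound 3 to compound 4 (0.11 log units; within the scatter), within the scatter. The estimate for compound 4 in this assay is 130 nM, with a range from 45 nM to 380 nM.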

Compound 4, half-maximal inhibitory concentration: 42 nM
Beside the measured number, compound 4's estimate is 3.1-fold (0.49 log units) above it; measured number below the stated range.
By their numbers in this assay, from the lowest: compounds 4 and 1 (each within the scatter of the next); then compound 3; then compound 2.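

In this assay the anilino group at this position, on an aromatic carbon next to the ring nitrogen and the ring oxygen, can be matched by a group without its six-membered aromatic ring of carbon only, with a 1.1-fold lower number from compound 1 to compound 4 (0.06 log units; within the scatter) as the result. The entering group also keeps a six-membered non-aromatic ring with 2 hetero atoms, yet it gives a 4.0-fold lower number from compound 3 to compound 4 (0.60 log units; beyond the scatter) and a 12-fold lower number from compound 2 to compound 4 (1.07 log units; beyond the scatter) in the same series, so a non-aromatic ring here does not by itself limit the reading. Nothing shown accounts for these differences.

Open, from the compounds shown here alone, is whether the five-membered aromatic ring carries the gain over compound 3. Also open, going by these compounds, is whether a plain piperazine or an unsubstituted morpholine at this position would read in this assay as compound 4 does.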